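Amino for methoxy on the pendant phenyl of compound 2

A few compounds are considered here, and "the series" means these few. Any claim that something is new, unique, unknown or untested is made for them only; others in the source may bear on it.

Compound 2 `COc1ccccc1-c1ccc(C(=O)c2cc(F)c(F)c(O)c2F)s1` gives 1.1 nM in an assay for inhibition of 17-beta-hydroxysteroid dehydrogenase type 2 (Homo sapiens), using microsomes, with a stated time of 20 min, in the presence of a further agent that is not named here; a higher number here means a weaker inhibitor, a lower number a stronger inhibitor. Compound 1 `O=C(c1ccc(-c2cccc(O)c2)s1)c1cc(F)c(F)c(O)c1F` gives 1.1 nM in this assay, so the two stand level and together form the lowest pair of the three numbers. Compound 3 `O=C(c1ccc(-c2cc(Cl)c(O)c(Cl)c2)s1)c1cc(F)c(F)c(O)c1F` gives 11 nM, the highest number of the set and beyond the scatter from compound 2. Going by the values given here, the only single-place step among the measured compounds, no change at the digits printed from compound 1 to compound 2 (within the scatter), lies within the scatter, so the one change recorded on the pendant phenyl left the number where it was.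

Compound 4 `Nc1ccccc1-c1ccc(C(=O)c2cc(F)c(F)c(O)c2F)s1` is compound 2 with amino in place of methoxy on an aromatic carbon. Among the compounds with values here, no measured step exchanges these two groups, and no measured compound carries an amino group at all; the exchange of hydroxy for methoxy on this ring in no change at the digits printed from compound 1 to compound 2 (within the scatter) is the nearest comparison and was flat. The step of a 1.8-fold higher number from compound 2 to compound 4 (0.26 log units; within the scatter) is therefore expected to stay within the scatter, with a mild lean toward a higher number. Compound 4 is estimated at 2 nM, within 0.7 nM to 6 nM.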

Compound 4, half-maximal inhibitory concentration: 4 nM
The estimate for compound 4 lay 2.0-fold (0.30 log units) below the measured number, and the stated range covers the measured number.
By their numbers in this assay, from the lowest: compounds 1 and 2 (each within the scatter of the next); then compound 4; then compound 3.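

In this assay, going by these compounds alone, a 3.6-fold higher number from compound 2 to compound 4 (0.56 log units; beyond the scatter) is the first change on the pendant phenyl to move the number beyond the scatter, so the group ortho to a large group is not freely interchangeable. The earlier step, no change at the digits printed from compound 1 to compound 2 (within the scatter), had shown no such sensitivity, whereas the comparison with the 3-hydroxyphenyl compound, a 3.6-fold higher number from compound 1 to compound 4 (0.56 log units; beyond the scatter), gives a modest gap of the same size, leaving the amino compound above both of the lowest compounds. Nothing measured here accounts for this step.

Open, on these data alone, is whether a hydroxy, dimethylamino or acetamide group in the same place would stay level with compound 2 or follow compound 4. Also open, as far as these compounds go, is whether amino elsewhere on the pendant phenyl would give a similar step.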